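Piperidine amide series: swapping the pyridyl amide substituent

The compounds below may be only part of what the source reports. "The series", "measured", "known", "first", "only" and "open" are said of these compounds alone.

Three compounds carry the shared core: compound 1 `CCOc1cc(CN2CCC(NC(=O)c3ccc(NC(C)C)nc3)CC2)cc(OCC)c1F`, compound 2 `CCOc1cc(CN2CCC(NC(=O)c3cncc(C)c3)CC2)ccc1C` and compound 3 `CCOc1cc(CN2CCC(NC(=O)c3ccc(N)nc3)CC2)ccc1C`. In a physicochemical assay for acid dissociation, read by spectrophotometry, compound 1 gives 7.84, the lowest of the three; compound 2 gives 8.08 and compound 3 gives 8.27. Among the compounds with values here, the one single-point step measured, a number 0.19 log units higher from compound 2 to compound 3 (within the scatter), is the only guide for the substituent on the carbonyl carbon.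

Compound 4 `CCOc1cc(CN2CCC(NC(=O)c3cncc(C)c3)CC2)cc(OCC)c1F` is not yet measured. It differs from compound 1 as follows: 5-methylpyridin-3-yl in place of 6-(isopropylamino)pyridin-3-yl on a carbonyl carbon. Because the reverse-direction step a number 0.19 log units higher from compound 2 to compound 3 (within the scatter) was small, the move toward a pyridyl lacking the amino-type donor is expected to lower the number only slightly, as a number 0.19 log units lower from compound 1 to compound 4 (within the scatter). For compound 4 the estimate in this assay is 7.65, between 7.35 and 7.95.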

Compound 4, acid dissociation constant: 7.7
Compound 4: the middle estimate sits 0.05 log units below what was measured, and the stated range covers the measured number.
By their numbers in this assay, from the lowest: compounds 4, 1, 2 and 3 (each within the scatter of the next, the first and the last beyond it).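

In this assay, the swap to 5-methylpyridin-3-yl on the carbonyl carbon gives a number 0.14 log units lower from compound 1 to compound 4 (within the scatter). This extends the reading to the core of compound 1, where losing the isopropylamino group and the hydrogen-bond donor it carries leaves the number within the scatter. On the other core, a number 0.19 log units higher from compound 2 to compound 3 (within the scatter), so neither single-place change at this position has moved the number beyond the scatter.

On these data alone, whether a carboxylic acid or a morpholine ring on the carbonyl carbon would do so stays open. Nothing available here bears on the reason for these small steps.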